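The source may hold more compounds than are shown below. What is called first, only, known or untested is meant among the compounds shown, and "the series" means these compounds.

Compound 1 `Cc1cc([Si](C)(C)C)c2cn[nH]c2c1`: 1700 nM
Compound 2 `OC(Cc1ccccc1)c1cccc2[nH]ncc12`: 7900 nM

Of the compounds shown here, two have been measured in an assay for binding affinity to Indoleamine 2,3-dioxygenase 1 (Homo sapiens), read by spectrophotometry, with a stated time of 30 min; a lower number here means tighter binding, a higher number weaker binding. Compound 1 gives 1700 nM, and compound 2 gives 7900 nM. Among the measured compounds shown here, compound 2 holds the higher number of the two; its only neighbour, compound 1, sits beyond the scatter below it.

Compound 3 `OC(Cc1ccccc1)c1cc(Br)cc2[nH]ncc12` differs from compound 2 by bromo in place of hydrogen on an aromatic carbon. For the measured compounds named here, no comparable step has been measured here, so the expectation rests on the change alone: a modest move toward a lower number is expected, at the edge of the scatter. The estimate for compound 3 is 3500 nM, with a range from 1000 nM to 12000 nM. This corresponds to an expected step of a 2.3-fold lower number from compound 2 to compound 3 (0.35 log units; beyond the scatter).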

Compound 3, dissociation constant: 140 nM
Compound 3: the middle estimate sits 25-fold (1.40 log units) above what was measured; the whole stated range lies above it.
By their numbers in this assay, from the lowest: compound 3; then compound 1; then compound 2.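

Placing a single bromo in place of hydrogen, on the aromatic carbon para to a fused ring and meta to the group of 9 heavy atoms, gives a 56-fold lower number from compound 2 to compound 3 (1.75 log units; beyond the scatter) in this assay, a large step. This carbon is therefore not indifferent to substitution: one added heavy atom is enough to shift the number strongly. Nothing available here accounts for the size of this step. From the compounds shown here alone, whether chloro, an amine or a carboxylic acid on the same carbon would give a step of similar size remains open.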